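The compounds below may be only part of what the source reports. "The series", "measured", "known", "first", "only" and "open" are said of these compounds alone.

The measured compounds:
compound 1, `COc1cc(F)c(NC(=O)c2ccnc(O)c2)cc1Nc1nccc(-c2cn(C)c3ccccc23)n1`, giving 11700 nM in a functional assay on A549 cells (Homo sapiens) for antiproliferative activity, read by MTT assay, with a stated time of 72 h; on this read-out higher numbers stand for weaker inhibition and lower numbers for stronger inhibition;
compound 2, `COc1ccc(C(=O)Nc2cc(Nc3nccc(-c4cn(C)c5ccccc45)n3)c(OC)cc2F)nc1`, giving 8200 nM;
compound 3, `COc1cc(N(C)CCN(C)C)c(NC(=O)c2ccnc(O)c2)cc1Nc1nccc(-c2cn(C)c3ccccc23)n1`, giving 11200 nM.

Compound 3 holds the second highest of the three numbers; its nearest neighbour is compound 1 (a 1.0-fold lower number from compound 1 to compound 3 (0.02 log units; within the scatter)) and compound 2 also lies within the scatter of it. Compound 4, `COc1cc(N(C)CCN(C)C)c(NC(=O)c2ccncn2)cc1Nc1nccc(-c2cn(C)c3ccccc23)n1`, differs from compound 3 by pyrimidin-4-yl in place of 2-hydroxypyridin-4-yl on a carbonyl carbon. Going by the values given here, the only measured step at the same place is a 1.4-fold lower number from compound 1 to compound 2 (0.15 log units; within the scatter), which stayed within the scatter; the step of a 1.0-fold lower number from compound 1 to compound 3 (0.02 log units; within the scatter) concerns another place. On that basis, the change to compound 4 is expected to produce no step beyond the scatter in this assay, that is a 1.1-fold lower number from compound 3 to compound 4 (0.05 log units; within the scatter). Compound 4 is therefore estimated at 10000 nM, within a range from 4000 nM to 25000 nM.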

Compound 4, half-maximal inhibitory concentration: 2530 nM
The estimate for compound 4 lay 4.0-fold (0.60 log units) above the measured number, outside the stated range (below it).
By their numbers in this assay, from the lowest: compound 4; then compounds 2, 3 and 1 (each within the scatter of the next).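

In this assay, going by these compounds alone, the group on the carbonyl carbon proves able to move the number: pyrimidin-4-yl in place of 2-hydroxypyridin-4-yl gives the first step beyond the scatter (a 4.4-fold lower number from compound 3 to compound 4 (0.65 log units; beyond the scatter)), whereas the earlier change at this place stayed within it (a 1.4-fold lower number from compound 1 to compound 2 (0.15 log units; within the scatter)). No measurement shown accounts for this step.

On these data alone, it remains open whether unsubstituted pyridin-4-yl would separate the loss of the hydroxyl from the gain of a ring nitrogen. Also open, as far as these compounds go, is whether pyrimidin-4-yl gives a similar step with fluoro in place of (2-(dimethylamino)ethyl)(methyl)amino.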